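Moving the ether from the chain onto the ring itself

The source may hold more compounds than are shown below. What is called first, only, known or untested is meant among the compounds shown, and "the series" means these compounds.

Two compounds share one core with a carboxylic acid tail and a benzyl-bearing side chain. Among the measured compounds shown here, in a functional assay on cells with prostaglandin E2 receptor EP4 subtype (Mus musculus) as the target (a lower number here means that less compound is needed, a higher number that more compound is needed for the effect), compound 1 `COCc1cccc(C[C@H](O)/C=C/[C@H]2[C@H](O)CC(=O)[C@@H]2SCCCSCC(=O)O)c1` gives 3.1 nM, and compound 2 `CCOCc1cccc(C[C@H](O)/C=C/[C@H]2[C@H](O)CC(=O)[C@@H]2SCCCSCC(=O)O)c1` gives 2.5 nM; the only step between them, a 1.2-fold lower number from compound 1 to compound 2 (0.09 log units; within the scatter), leaves the two numbers indistinguishable, so compound 2 stands beside compound 1 rather than apart from it.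

Compound 3 `COc1ccccc1C[C@H](O)/C=C/[C@H]1[C@H](O)CC(=O)[C@@H]1SCCCSCC(=O)O` differs from compound 2 by 2-methoxyphenyl in place of 3-(ethoxymethyl)phenyl on a saturated chain carbon, two bonds along the chain from a double-bonded chain carbon and an oxygen on a saturated carbon. For the measured compounds named here, no measured step touches this change: the single step that exists, from compound 1 to compound 2, alters only the chain on the ring substituent and stays within the scatter, so it gives no direction for a change of the ring substitution pattern itself. The account therefore expects at most a modest step, a 2.0-fold higher number from compound 2 to compound 3 (0.30 log units; within the scatter), with the direction left open. Compound 3 is estimated at 5 nM, within a range from 1.5 nM to 20 nM.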

Compound 3, half-maximal effective concentration: 580 nM
Compound 3: the middle estimate sits 120-fold (2.06 log units) below what was measured; measured number outside the range, above it.
By their numbers in this assay, from the lowest: compounds 2 and 1 (each within the scatter of the next); then compound 3.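

Compound 1 and compound 2 showed only that the chain on the ring substituent could change with no effect beyond the scatter. In this assay the 2-methoxyphenyl group brings a 230-fold higher number from compound 2 to compound 3 (2.37 log units; beyond the scatter) and a 190-fold higher number from compound 1 to compound 3 (2.27 log units; beyond the scatter) at the same saturated chain carbon, so the aryl group at this position can strongly shift the concentration needed. Nothing available accounts for this large step.

The change replaces the whole aryl group in one step, so the compounds cannot separate the loss of the ethoxymethyl or methoxymethyl chain from the new placement of an oxygen-bearing group on the ring. They also leave open how an amine, a carboxylic acid or a longer ether chain on that phenyl ring would behave.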